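Moving the chloro on the pendant ring: clearance notes

A few compounds are considered here, and "the series" means these few. Any claim that something is new, unique, unknown or untested is made for them only; others in the source may bear on it.

Among the measured compounds shown here, compound 2 `Cn1c(-c2ccc(Cl)cc2)cnc1NC(=O)c1ncc[nH]1` is the only member of the set with a number in an ADME assay on microsomes from liver (Mus musculus) for metabolic stability; a higher number here means faster removal of the compound, a lower number slower removal; in this assay compound 2 gives 41 uL/min. Compound 1 `Cn1c(-c2ccccc2)cnc1NC(=O)c1ncc[nH]1` reaches only a limit of the assay, > 866 uL/min, as recorded in the limit of > 866 uL/min in this assay, at which 1 of the 2 values shown sits. For the measured compounds named here, the one measured step, an at least 21-fold lower number from compound 1 to compound 2 (1.32 log units; beyond the scatter), sets the scale for what a single change on the pendant ring can do. Compound 3 `Cn1c(-c2cccc(Cl)c2)cnc1NC(=O)c1ncc[nH]1` has not been measured; it differs from compound 2 by 3-chlorophenyl in place of 4-chlorophenyl on an aromatic carbon. Going by the values given here, no measured step covers a rearrangement of this kind, so the measured step serves only as an upper bound for its size. A step upward, smaller than the measured one, is expected: a 3.7-fold higher number from compound 2 to compound 3 (0.56 log units; beyond the scatter). Compound 3 is therefore estimated at 150 uL/min, with a range from 40 uL/min to 600 uL/min.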

Compound 3, intrinsic clearance in a liver preparation (reported as CLH), per the amount of preparation that the assay uses: 21 uL/min
Estimate against measurement, compound 3: 7.1-fold (0.85 log units) above; the whole stated range lies above it.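

In this assay the two chloro placements cannot be told apart: the rearrangement gives a 2.0-fold lower number from compound 2 to compound 3 (0.29 log units; within the scatter) and so leaves 4-chlorophenyl and 3-chlorophenyl level. The large effect of adding chloro to the pendant ring therefore does not rest on the 4-chlorophenyl arrangement alone, since the second placement also gives an at least 41-fold lower number from compound 1 to compound 3 (1.61 log units; beyond the scatter) in this assay. Compound 1 stands at a limit, so the size of this step is only a bound: the limit of > 866 uL/min in this assay, at which 1 of the 3 values shown sits.

As far as these compounds go, whether the lower numbers belong to chloro itself or would also follow with fluoro, methoxy or a nitrile on the same ring remains open. How far they hold with a polar group such as an amine or a carboxylic acid on that ring is also unresolved.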